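This account rests on a few compounds, and the source may have more. Where it says the series, first, only, none or still open, it means among the compounds named here.

Compound 1 `CCOc1ccc(NS(=O)(=O)c2ccc(Cl)cc2)cc1` and compound 2 `Cc1ccc(S(=O)(=O)Nc2ccc(NS(=O)(=O)c3ccc(F)cc3)cc2)cc1` share a sulfonamide-linked aromatic frame with compound 3 `O=S(=O)(Nc1ccc(NS(=O)(=O)c2ccc(F)cc2)cc1)c1ccc(F)cc1`. In an assay for inhibition of liver carboxylesterase 1 (Homo sapiens), read by spectrophotometry (on this read-out higher numbers stand for weaker inhibition and lower numbers for stronger inhibition), compound 1 gives only a limit, > 100000 nM. In this assay compound 2 likewise gives only a limit, > 100000 nM. Compound 3 also returns only a limit in this assay, > 100000 nM. Among the measured compounds shown here, the one measured step, a step that the two limits leave unreadable from compound 2 to compound 3, is therefore unreadable, and this is because of the limit of > 100000 nM in this assay, at which 3 of the 3 values shown sit. Compound 3 thus stands at the edge of what this assay reports, with no readable value among its neighbours.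

Compound 4 `Cc1ccc(C(=O)O)cc1S(=O)(=O)Nc1ccc(NS(=O)(=O)c2ccc(F)cc2)cc1` differs from compound 3 in one place: 5-carboxy-2-methylphenyl in place of 4-fluorophenyl on a sulfonyl sulfur. For the measured compounds named here, no measured step bears on this change; the single step in hand gives no readable size, so no direction beyond the scatter can be drawn from it. The account therefore expects compound 4 to remain near the limit, with an at least 1.2-fold lower number from compound 3 to compound 4 (0.09 log units; that floor lies within the scatter) as the estimated shift. For compound 4 the estimated value in this assay is 80000 nM, expected to lie between 10000 nM and 300000 nM.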

Compound 4, inhibition constant: > 100000 nM
Compound 4: a limit, no number (the forecaster's own chance of this, stated with the estimate: 55%); middle value at least 1.2-fold (0.09 log units) away from the limit.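

Neither the step from compound 3 to compound 4 nor the one from compound 2 to compound 4 can be read, because compound 4 also gives only a limit: the limit of > 100000 nM in this assay, at which 4 of the 4 values shown sit.

The compounds shown leave open whether any change to the shared core would give a readable number in this assay.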